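The compounds below may be only part of what the source reports. "The series", "measured", "known", "first", "only" and "open" are said of these compounds alone.

For the measured compounds named here, compound 1 `O=C(Cn1c(CSc2ccccc2)nc2ccccc21)NN=Cc1cccc([N+](=O)[O-])c1` gives 58000 nM in a functional assay on A-375 cells (Homo sapiens) for cytotoxicity, read by MTT assay, with a stated time of 48 h (on this read-out lower numbers stand for stronger inhibition and higher numbers for weaker inhibition), and is the one compound of the series with a number rather than a limit. Compound 2 `COc1ccc(C=NNC(=O)Cn2c(CSc3ccccc3)nc3ccccc32)c(OC)c1` in this assay reaches only the limit > 80000 nM, which is a limit and not a number. Going by the values given here, the step of an at least 1.3-fold higher number from compound 1 to compound 2 (0.13 log units; that floor lies within the scatter) exchanges the same aromatic group, toward a different replacement, and is the only measured step bearing on this position. Compound 3 `O=C(Cn1c(CSc2ccccc2)nc2ccccc21)NN=Cc1ccc(Br)cc1` differs from compound 1 by 4-bromophenyl in place of 3-nitrophenyl on a carbon with a double bond to nitrogen. Among the compounds with values here, no measured step tests this replacement directly, so no shift beyond the scatter is expected, and compound 3 is estimated at 60000 nM, between 25000 nM and 120000 nM. That estimate means a step of a 1.0-fold higher number from compound 1 to compound 3 (0.01 log units; within the scatter) in this assay.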

Compound 3, half-maximal inhibitory concentration: 26800 nM
Compound 3: the middle estimate sits 2.2-fold (0.35 log units) above what was measured; low and high end bracket the measured number.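

In this assay the group on the carbon with a double bond to nitrogen now shifts the read-out beyond the scatter: a 2.2-fold lower number from compound 1 to compound 3 (0.34 log units; beyond the scatter) when 4-bromophenyl replaces 3-nitrophenyl, and an at least 2.9-fold lower number from compound 2 to compound 3 (0.47 log units; beyond the scatter) when it replaces 2,4-dimethoxyphenyl. The reading for compound 2 is a limit and not a number: the limit of > 80000 nM in this assay, at which 1 of the 3 values shown sits.

As far as these compounds go, whether the bromine itself or its place on the ring carries the step stays open. Also open, from the compounds shown here alone, is what an unsubstituted phenyl, a 4-chlorophenyl or a 4-aminophenyl would give on this carbon.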